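The source may report more compounds than this note shows. Statements on the series, on what has been measured and on what is new or still open speak of the compounds shown alone.

Compound 1 `CCN(CC)CN1C(=O)/C(=N/NC(N)=S)c2cc(Cl)ccc21` was tested in an ADME assay on HeLa cells (Homo sapiens) for cytotoxicity (on this read-out lower numbers stand for higher toxicity in this test and higher numbers for lower toxicity in this test), where compound 1 gives > 100000 nM, a limit of the assay rather than a number. Compound 2 `CCN(CC)CN1C(=O)/C(=N/NC(=S)Nc2ccc(C)cc2)c2ccccc21` gives >= 20000 nM in this assay, likewise only a limit. Compound 1 therefore stands at a limit (the limit of > 100000 nM in this assay, at which 1 of the 2 values shown sits). Compound 2 stands at another limit (the limit of >= 20000 nM in this assay, at which 1 of the 2 values shown sits). Compound 3 `CCN(CC)CN1C(=O)/C(=N/NC(=S)Nc2ccc(OC)cc2)c2cc(Cl)ccc21` differs from compound 1 by 4-methoxyphenyl in place of hydrogen on an amide-type nitrogen. Compound 2 carries a comparable group on the amide-type nitrogen and still shows no toxicity in range. The step of a number no higher from compound 1 to compound 3 (the limit leaves the size open) is expected to stay within the scatter. Compound 3 is expected at 100000 nM, between 30000 nM and 200000 nM.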

Compound 3, minimum cytotoxic concentration: 4000 nM
Beside the measured number, compound 3's estimate is 25-fold (1.40 log units) above it, and the stated range ends above it.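

In this assay, placing 4-methoxyphenyl on the amide-type nitrogen gives an at least 25-fold lower number from compound 1 to compound 3 (1.39 log units; beyond the scatter), so this position is not indifferent to what it carries. Among the compounds shown here, compound 3 is also the first compound here to give a number rather than a limit, which brings toxicity in this test into measurable range. Compound 1 sits at a limit of the assay, so the full size of the step stays open: the limit of > 100000 nM in this assay, at which 1 of the 3 values shown sits.

Going by these compounds, whether a plain phenyl ring or a short alkyl chain on this nitrogen would lower the number as well remains open, and so does the contribution of the methoxy group.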